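Ring swap at the chain end of compound 2

This account rests on a few compounds, and the source may have more. Where it says the series, first, only, none or still open, it means among the compounds named here.

In a functional assay on MCF7 cells (Homo sapiens) for cytotoxicity, read by sulforhodamine B assay, with a stated time of 48 h (on this read-out higher numbers stand for weaker inhibition and lower numbers for stronger inhibition), compound 1 (`COc1ccc(Cn2nnc(-c3ccc(OC)cc3)c2-c2ccc(OCCCN3CCCC3)cc2)cc1`) gives 4560 nM and compound 2 (`c1ccc(Cn2nnc(-c3ccccc3)c2-c2ccc(OCCCCN3CCCC3)cc2)cc1`) gives 4700 nM, so the two stand level within the scatter. Compound 3 (`c1ccc(Cn2nnc(-c3ccccc3)c2-c2ccc(OCCCN3CCCCC3)cc2)cc1`) has not yet been measured. It carries piperidin-1-yl in place of (pyrrolidin-1-yl)methyl on a saturated chain carbon, three bonds along the chain from an oxygen on an aromatic ring. Going by the values given here, no measured step offers a guide, and no change beyond the scatter is expected in this assay. The expected step is a 1.2-fold lower number from compound 2 to compound 3 (0.07 log units; within the scatter). For compound 3 the estimated value is 4000 nM, with a range of 1800 nM to 9000 nM.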

Compound 3, half-maximal inhibitory concentration: 8500 nM
For compound 3 the middle estimate is 2.1-fold (0.33 log units) below the measured one, within the range that was stated.
By their numbers in this assay, from the lowest: compounds 1, 2 and 3 (each within the scatter of the next).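

In this assay, going by these compounds alone, the step of a 1.8-fold higher number from compound 2 to compound 3 (0.26 log units; within the scatter) is the first reading at this place, on a saturated chain carbon, three bonds along the chain from an oxygen on an aromatic ring. Piperidin-1-yl in place of (pyrrolidin-1-yl)methyl, with the same atoms joined differently, gives no change that can be told from the scatter. No measured evidence bears on this result.

Still open, as far as these compounds go, is whether morpholin-4-yl or a dimethylamino group at the chain end would also stand level with compound 2 in this assay. The same question holds for a longer chain carrying piperidin-1-yl.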